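The compounds below may be only part of what the source reports. "The series", "measured", "known", "first", "only" and "open" are said of these compounds alone.

Measured so far:
- compound 1, `CCCn1c(CN2CCN(c3ncc(Cl)cn3)CC2)nc2ccccc21` — 794 nM
- compound 2, `Cn1c(CN2CCC(c3ccccc3)CC2)nc2ccccc21` — 200 nM
- compound 3, `Cn1c(CN2CCN(c3ccc(Cl)cc3F)CC2)nc2ccccc21` — 126 nM

In an assay on CHO cells with metabotropic glutamate receptor 2 (Homo sapiens) as the target, read by FLIPR (on this read-out lower numbers stand for an effect already at smaller amounts and higher numbers for an effect only at larger amounts of compound), compound 3 gives the lowest of the three numbers. The nearest is compound 2, whose value lies within the usual scatter of compound 3, so no order between those two can be claimed. Compound 1 lies beyond the scatter and stands clearly at the higher end; compound 1 also differs from compound 3 at more than one place, so its gap tells nothing about any single change.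

The next step is compound 4, `Cn1c(CN2CCN(c3ccccc3F)CC2)nc2ccccc21`. It differs from compound 3 in one place: hydrogen in place of chloro on an aromatic carbon. For the measured compounds named here, no pair of measured compounds differs in only this way, so the size of this step in this assay is unknown from the numbers at hand.

With the chloro removed and the rest of the molecule held, the expected step from compound 3 to compound 4 is a modest move toward higher numbers, a 2.0-fold higher number from compound 3 to compound 4 (0.30 log units; within the scatter), a change that may not exceed the scatter. Compound 4 is thus estimated at 250 nM in this assay, with a range from 90 nM to 700 nM.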

Compound 4, half-maximal effective concentration: 794 nM
Beside the measured number, compound 4's estimate is 3.2-fold (0.50 log units) below it; measured number outside the range, above it.
By their numbers in this assay, from the lowest: compounds 3 and 2 (each within the scatter of the next); then compounds 1 and 4 (each within the scatter of the next).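

In this assay the series now has its first step at a single place: hydrogen in place of chloro on an aromatic carbon gives a 6.3-fold higher number from compound 3 to compound 4 (0.80 log units; beyond the scatter) and this step lies beyond the scatter. For the compounds shown here, this shows that, with the fluoro group and the rest of the molecule held, the position para to the large group and meta to the fluoro group is not indifferent to what it carries, and that the chloro there goes with the lower number; the earlier compounds, none of which differed in only one place, could not show this. No measurement at hand offers a reason for the size of this step.

From the compounds shown here alone, it remains open whether this step belongs to chloro itself or would also appear with another group at the same position, such as bromo, methyl, methoxy, nitrile or trifluoromethyl. Going by these compounds, it also remains open whether chloro would give a step of similar size on the 2-fluorophenyl group alone, that is, with the fluoro replaced by hydrogen, or whether the step depends on the fluoro group being present.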